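Swapping a dichlorobenzyl arm for an anilinomethyl group

This account rests on a few compounds, and the source may have more. Where it says the series, first, only, none or still open, it means among the compounds named here.

Measured compounds:
Compound 1, `Cc1ccc(S(=O)(=O)N(Cc2nnc(Cc3ccccc3Cl)o2)c2cccc(Cl)c2C)cc1`: 79.4 nM
Compound 2, `Cc1ccc(S(=O)(=O)N(Cc2nnc(Cc3ccc(Cl)cc3Cl)o2)c2cccc(Cl)c2C)cc1`: 63.1 nM

In an assay on CHO cells for displacement of a labelled ligand from prostaglandin E2 receptor EP1 subtype (Homo sapiens) (on this read-out lower numbers stand for stronger inhibition and higher numbers for weaker inhibition), compound 1 gives 79.4 nM, and compound 2 gives 63.1 nM. For the measured compounds named here, the only structural step between them is a 1.3-fold lower number from compound 1 to compound 2 (0.10 log units; within the scatter), so these two numbers cannot be told apart. Going by the values given here, compound 2 has the lowest number of the two, but its one neighbour, compound 1, sits within the scatter of it, and nothing further can be read from this pair.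

Compound 3, `COc1ccc(NCc2nnc(CN(c3cccc(Cl)c3C)S(=O)(=O)c3ccc(C)cc3)o2)cc1`, departs from compound 2 in a different place: (4-methoxyphenyl)amino in place of 2,4-dichlorophenyl on a saturated chain carbon bound to an aromatic carbon. Among the compounds with values here, no measured step touches this part of the molecule; the single step known, from compound 1 to compound 2, concerns a chlorine elsewhere and was itself within the scatter. Within the data shown here, the expectation for compound 3 therefore rests on no direct precedent. The change is large and brings a new hydrogen-bond donor; a broad range is appropriate. A step of a 2.5-fold higher number from compound 2 to compound 3 (0.40 log units; beyond the scatter) is expected, most likely toward a higher number. The estimate for compound 3 in this assay is 160 nM, within a range from 40 nM to 630 nM.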

Compound 3, half-maximal inhibitory concentration: 20 nM
Beside the measured number, compound 3's estimate is 8.0-fold (0.90 log units) above it; the whole stated range lies above it.
By their numbers in this assay, from the lowest: compound 3; then compounds 2 and 1 (each within the scatter of the next).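

The position on a saturated chain carbon bound to an aromatic carbon can take far more than the small chlorine change seen so far. In this assay, placing (4-methoxyphenyl)amino there instead of 2,4-dichlorophenyl gives a 3.2-fold lower number from compound 2 to compound 3 (0.50 log units; beyond the scatter) as the step, and placing it there instead of 2-chlorophenyl gives a 4.0-fold lower number from compound 1 to compound 3 (0.60 log units; beyond the scatter) as the step. Unlike the chlorine change, both of these steps lie beyond the scatter, so an arm carrying one hydrogen-bond donor, with no chlorine on its ring, is not merely accepted here but gives the lowest number of the three compounds, although nothing shown explains why.

The swap alters several things at once, bringing in the amine nitrogen and the methoxy group while removing the chlorines, so the compounds shown cannot say which of these changes matters. A plain phenylamino group would test the amine nitrogen without the methoxy group, while a 4-methoxybenzyl group would test the methoxy group without the amine nitrogen, and each would help to pull these contributions apart.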